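Methyl Ether Versus Free Phenol in Kinase Inhibition

The compounds below may be only part of what the source reports. "The series", "measured", "known", "first", "only" and "open" are said of these compounds alone.

Three compounds have been measured in an assay on HEK293 cells for inhibition of protein kinase C zeta type (Homo sapiens), read by 33P incorporation, with a stated time of 40 min, tested at 20 uM, in the presence of a further agent that is not named here; a lower number here means less inhibition, a higher number more inhibition at the concentration tested (going by the name of the read-out):

compound 1 `COc1ccc(C2=NN(c3ccc(Cl)cc3)C(c3cccc(Cl)c3)C2)cc1` — 39%
compound 2 `Oc1ccc(C2=NN(c3ccc(Cl)cc3)C(c3cccc(Cl)c3)C2)cc1` — 71.8%
compound 3 `Oc1ccc(C2=NN(c3cccc(Cl)c3)C(c3ccc(Cl)cc3)C2)cc1` — 86.2%

Compound 2 and compound 3 are built from the same atoms joined differently; the difference between the two cores is not broken down here. Compound 3 gives the highest number of the three, and both of its gaps, to compound 2 and to compound 1, lie beyond the usual scatter. Within the data shown here, the one change seen twice is methyl in place of hydrogen on an oxygen on an aromatic ring: it produced a number 32.8 percentage points lower from compound 2 to compound 1 (beyond the scatter).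

Compound 4 `COc1ccc(C2=NN(c3cccc(Cl)c3)C(c3ccc(Cl)cc3)C2)cc1` carries the same change relative to compound 3, namely (methyl in place of hydrogen on an oxygen on an aromatic ring), at a place described in the same words. Because the earlier instance gave a number 32.8 percentage points lower from compound 2 to compound 1 (beyond the scatter), a step of similar size is expected, a number 33.2 percentage points lower from compound 3 to compound 4 (beyond the scatter), though it rests on a single prior example. Compound 4 is therefore estimated at 53% in this assay, with a range from 35% to 70%.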

Compound 4, a percentage reported as inhibition, at one concentration (the size of the read-out at that concentration, not a potency): 30.8%
The estimate for compound 4 lay 22.2 percentage points above the measured number; the measured number lies below the stated range.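

Going from hydroxy to methoxy in this assay gave a number 55.4 percentage points lower from compound 3 to compound 4 (beyond the scatter), so the direction seen on the first core carried over to the second. The size of the step did not carry over: the same change on two cores in this assay, a number 32.8 percentage points lower (beyond the scatter) from compound 2 to compound 1 and a number 55.4 percentage points lower (beyond the scatter) from compound 3 to compound 4, 22.6 percentage points apart, beyond the scatter of two such steps

These two pairs therefore support expecting a lower number from this change on these two cores, but they cannot predict its size on a further core or explain why the two steps differ. Still open, going by these compounds, is how an ethoxy group, which has a longer chain on the oxygen, or an amine in place of the hydroxy would read on either core.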